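The source may report more compounds than this note shows. Statements on the series, on what has been measured and on what is new or still open speak of the compounds shown alone.

Of the compounds shown here, three sharing a core have been read in an ADME assay on microsomes from liver (Rattus norvegicus, strain Sprague-Dawley) for metabolic stability, read by LC-MS, with a stated time of 15 min, tested at 20 uM; a higher number here means that more of the compound is left, a lower number that less of the compound is left. Compound 1 `O=C(OCc1ccccc1)c1coc(-c2ccccc2)n1` gives 2.7%, compound 2 `O=C(Oc1ccccc1N1CCCC1)c1coc(-c2ccccc2)n1` gives 11.2%, and compound 3 `CCC(C)c1ccccc1OC(=O)c1coc(-c2ccccc2)n1` gives 8.3%. Compound 3 stands within the scatter of both compound 1 and compound 2, so this assay does not separate these three compounds.

Still unmeasured is compound 4 `CC(C)(C)c1ccccc1OC(=O)c1coc(-c2ccccc2)n1`. It differs from compound 3 in one place, with tert-butyl in place of sec-butyl on an aromatic carbon, ortho to a large group (tert-butyl in place of sec-butyl on an aromatic carbon). The two have the same atoms, joined differently.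

Going by the values given here, one measured step bears on this place: a number 2.9 percentage points lower from compound 2 to compound 3 (within the scatter). That exchange of sec-butyl for pyrrolidin-1-yl stays within the scatter. Among the compounds with values here, no measured pair compares sec-butyl with tert-butyl directly, so this evidence is indirect and the range must remain wide. On this evidence, no step beyond the scatter is expected, and no direction can be firmly assigned. The estimated step is small, a number 1.7 percentage points higher from compound 3 to compound 4 (within the scatter). For compound 4 the estimated value is 10%, with an expected range from 3% to 25%.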

Compound 4, percent of the compound remaining: 6.9%
Estimate against measurement, compound 4: 3.1 percentage points above, within the range that was stated.
By their numbers in this assay, from the lowest: compounds 1, 4, 3 and 2 (each within the scatter of the next).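

In this assay, going by these compounds alone, the first direct comparison at this place, tert-butyl in place of sec-butyl on an aromatic carbon, gives a number 1.4 percentage points lower from compound 3 to compound 4 (within the scatter), so this reconnection of the same carbon atoms is not resolved by the read-out. Taken against pyrrolidin-1-yl, tert-butyl gives a number 4.3 percentage points lower from compound 2 to compound 4 (within the scatter), which joins a number 2.9 percentage points lower from compound 2 to compound 3 (within the scatter) and leaves neither butyl group separated from pyrrolidin-1-yl at this place. Nothing available offers a cause for how close these readings lie.

For the three compounds with a substituent at this place, the exchanges seen so far, one between two branched butyl isomers and two between a butyl group and pyrrolidin-1-yl, all stay within the usual scatter, so this place has yet to show any effect on the percent of compound remaining. Open, on these data alone, are whether a carboxylic acid or a morpholine on this aromatic carbon would give a step beyond the scatter, and whether an amide in place of the ester linking the shared core to this aromatic ring would do so.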